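The source may hold more compounds than are shown below. What is called first, only, known or untested is meant among the compounds shown, and "the series" means these compounds.

Measured in a functional assay on HL-60 cells (Homo sapiens) for antiproliferative activity, read by MTT assay, with a stated time of 72 h; on this read-out lower numbers stand for stronger inhibition and higher numbers for weaker inhibition:
- Compound 1 `COc1cc(-n2ncnc2-c2ccc(OC(F)(F)F)cc2)cc(OC)c1OC`: > 10000 nM, a limit.
- Compound 2 `COc1cc(-n2ncnc2-c2ccc(Cl)c(Cl)c2)cc(OC)c1OC`: > 10000 nM, a limit.
- Compound 3 `COc1cc(-n2ncnc2-c2cccc(F)c2)cc(OC)c1OC`: > 10000 nM, a limit.

Compound 3 has no numeric position in this assay, since its result is a limit and not a number. The other two entries give it no numeric reference point either: the limit of > 10000 nM in this assay, at which 3 of the 3 values shown sit.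

The next compound to be read is compound 4 `COc1cc(-n2ncnc2-c2ccc(F)cc2)cc(OC)c1OC`. The change is 4-fluorophenyl in place of 3-fluorophenyl on an aromatic carbon. The two compounds have the same atoms, joined differently, with 4-fluorophenyl in place of 3-fluorophenyl on an aromatic carbon of the five-membered aromatic ring with 3 nitrogen.

Going by the values given here, one measured step bears on this change: a step that the two limits leave unreadable from compound 2 to compound 3. Both ends of that step are limits, so it has no readable size and offers no direction. The series therefore gives no support for a step beyond the scatter in this assay, and none is expected. Compound 4 is expected to remain in the same region as compound 3, and it may well be reported only as a limit. The expected change is a number no higher from compound 3 to compound 4 (the limit leaves the size open). For compound 4 the estimated value is 10000 nM, with an expected range of 3000 nM to 30000 nM.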

Compound 4, half-maximal inhibitory concentration: > 10000 nM
Compound 4: only a limit was reported; the forecaster's own chance of this, stated with the estimate: 80%; the middle value sits exactly at the limit.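

Compound 4 is reported only as a limit in this assay, as are compound 1, compound 2 and compound 3, so no step among these compounds can be read: the limit of > 10000 nM in this assay, at which 4 of the 4 values shown sit.

The compounds shown leave open whether 4-fluorophenyl and 3-fluorophenyl differ at all on this read-out, and whether any group at this place on the shared core gives a numeric value.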